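Exchanging the aryl group on the amine nitrogen

A few compounds are considered here, and "the series" means these few. Any claim that something is new, unique, unknown or untested is made for them only; others in the source may bear on it.

Among the compounds with values here, compound 2 `S=c1oc(-c2ccc3c(c2)OCCO3)nn1CNc1ccc(Br)cc1Br` gives 6410 nM in a functional assay, with a stated time of 6 min (a higher number here means a weaker inhibitor, a lower number a stronger inhibitor), the lowest of the two numbers so far, though within the scatter of compound 1 `S=c1oc(-c2ccc3c(c2)OCCO3)nn1CNc1ccc(Cl)cc1`, which gives 7270 nM in this assay; the step of a 1.1-fold lower number from compound 1 to compound 2 (0.05 log units; within the scatter) lies within the scatter. Compound 3 `O=[N+]([O-])c1ccccc1NCn1nc(-c2ccc3c(c2)OCCO3)oc1=S` differs from compound 2 by 2-nitrophenyl in place of 2,4-dibromophenyl on an amine nitrogen. Within the data shown here, the only step that bears on this change is the one between compound 1 and compound 2, which also exchanged the aryl group on the amine nitrogen and barely moved the number, so no step beyond the scatter is expected in this assay. Compound 3 is estimated at 6500 nM, ranging from 2500 nM to 17000 nM, an expected step of a 1.0-fold higher number from compound 2 to compound 3 (0.01 log units; within the scatter).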

Compound 3, half-maximal inhibitory concentration: 10900 nM
The estimate for compound 3 lay 1.7-fold (0.22 log units) below the measured number, and the stated range covers the measured number.
By their numbers in this assay, from the lowest: compounds 2, 1 and 3 (each within the scatter of the next).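

Placing 2-nitrophenyl on the amine nitrogen gives a 1.7-fold higher number from compound 2 to compound 3 (0.23 log units; within the scatter) and a 1.5-fold higher number from compound 1 to compound 3 (0.18 log units; within the scatter) in this assay, so both steps stay within the scatter. The halogens can thus be exchanged for a nitro-bearing aryl group, which adds two hydrogen-bond acceptors, with no step beyond the scatter among these three compounds. Nothing available here speaks to the reason for this. From the compounds shown here alone, whether an aryl group carrying a carboxylic acid or an amine, or a longer chain in place of the aryl group, would give a step beyond the scatter remains open.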